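Removing a Chloro Group from Compound 1 and Cytotoxicity

A few compounds are considered here, and "the series" means these few. Any claim that something is new, unique, unknown or untested is made for them only; others in the source may bear on it.

Compound 1 `Cc1cc(-c2ccc(C#N)cc2)cc(Cl)c1Oc1ccnc(Nc2ccc(C#N)cc2)n1` was tested in a functional assay on MT4 cells (Homo sapiens) for cytotoxicity, read by MTT assay, with a stated time of 5 days; on this read-out higher numbers stand for lower toxicity in this test and lower numbers for higher toxicity in this test. In this assay compound 1 gives > 285000 nM, which is a limit of the assay and not a number. Two of the three values measured are limits (the limit of > 285000 nM in this assay, at which 1 of the 3 values shown sits), and compound 1 sits at one of them. Compound 3 `N#Cc1ccc(Nc2nccc(Oc3ccc(-c4ccc(C#N)cc4)c(C(F)(F)F)c3)n2)cc1` gives > 273000 nM in this assay, again a limit (the limit of > 273000 nM in this assay, at which 1 of the 3 values shown sits). Compound 2 `N#Cc1ccc(Nc2nccc(Oc3ccc(-c4ccc(C#N)c(Cl)c4)cc3Cl)n2)cc1` gives 14900 nM in this assay. Compound 4 `Cc1cc(-c2ccc(C#N)cc2)ccc1Oc1ccnc(Nc2ccc(C#N)cc2)n1` has not yet been measured; it differs from compound 1 in one place: hydrogen in place of chloro on an aromatic carbon. Within the data shown here, no measured pair isolates this change. The step of an at least 1.1-fold lower number from compound 1 to compound 4 (0.05 log units; that floor lies within the scatter) is expected to be none beyond the scatter, since compound 1 already sits at a limit. Compound 4 is expected to give about 250000 nM in this assay, somewhere from 80000 nM to 450000 nM.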

Compound 4, half-maximal cytotoxic concentration: > 310000 nM
Compound 4: a limit, no number (the forecaster's own chance of this, stated with the estimate: 65%); middle value at least 1.2-fold (0.09 log units) away from the limit.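

Among these compounds, compound 1 and compound 4 both give limits rather than numbers in this assay, and no step between them can be read. The compounds shown leave open whether hydrogen in place of chloro changes the cytotoxicity at all.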